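Bromine on the Core: From Compound 2 to Compound 3

The source may report more compounds than this note shows. Statements on the series, on what has been measured and on what is new or still open speak of the compounds shown alone.

Compound 1 `COc1ccc2[nH]cc(C(=O)/C(C#N)=C/C=C(\Cl)c3ccc(OC)c(OC)c3)c2c1` in a functional assay for inhibition, with a stated time of 30 min, tested at 1 mM (a higher number here means more inhibition at the concentration tested (going by the name of the read-out), a lower number less inhibition), gives 34.2%. Compound 2 `COc1ccc(/C(Cl)=C/C=C(\C#N)C(=O)c2c[nH]c3ccccc23)cc1OC` in this assay gives 15.8%. For the measured compounds named here, the single measured step, a number 18.4 percentage points lower from compound 1 to compound 2 (beyond the scatter), is modest, and it leaves compound 2 with the lower of the two numbers, compound 1 standing higher. Compound 3 `COc1ccc(/C(Cl)=C/C=C(\C#N)C(=O)c2c[nH]c3ccc(Br)cc23)cc1OC` differs from compound 2 by bromo in place of hydrogen on an aromatic carbon. That measured step concerns a methoxy group rather than a bromo group, so it offers little direct guidance. The step expected here, a number 4.2 percentage points higher from compound 2 to compound 3 (within the scatter), is therefore taken as none beyond the scatter. Compound 3 is estimated at 20%, within a range from 5% to 40%.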

Compound 3, a percentage reported as inhibition, at one concentration (the size of the read-out at that concentration, not a potency): 11.8%
The estimate for compound 3 lay 8.2 percentage points above the measured number; the range from low to high includes it.
By their numbers in this assay, from the lowest: compounds 3 and 2 (each within the scatter of the next); then compound 1.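

In this assay, bromo in place of hydrogen on this aromatic carbon gives a number 4 percentage points lower from compound 2 to compound 3 (within the scatter), so the two groups cannot be told apart here. Bromo in place of methoxy on the same carbon gives a number 22.4 percentage points lower from compound 1 to compound 3 (beyond the scatter), so among these three groups, only methoxy separates from the others. No available evidence explains this result. Still open, as far as these compounds go, is whether an amine or a carboxylic acid on this carbon would read like methoxy or like hydrogen and bromo. A hydroxyl group or a longer ether chain poses the same question.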